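A few compounds are considered here, and "the series" means these few. Any claim that something is new, unique, unknown or untested is made for them only; others in the source may bear on it.

Compound 1 `COc1ccc(OC(C)CNC(C)=O)cc1` gives 12600 nM in an assay on NIH3T3 cells for displacement of a labelled ligand from melatonin receptor type 1B (Homo sapiens), with a stated time of 90 min; a lower number here means a stronger inhibitor, a higher number a weaker inhibitor.
Compound 2 `COc1ccccc1OC(C)CNC(C)=O` gives 5130 nM in this assay.

Of the two measured compounds, compound 2 has the lower number; compound 1 sits at a higher number, beyond the scatter. Compound 3 `CC(=O)NCC(C)Oc1ccccc1` differs from compound 2 by hydrogen in place of methoxy on an aromatic carbon, a hydrogen in place of methoxy on an aromatic carbon, ortho to a group of 8 heavy atoms. Within the data shown here, no measured pair shows this step, so its size is not known. Compound 3 is expected to give a somewhat higher number, and the estimate for compound 3 is 10000 nM, within 3000 nM to 40000 nM, which would mean an expected step of a 1.9-fold higher number from compound 2 to compound 3 (0.29 log units; within the scatter).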

Compound 3, inhibition constant: 1150 nM
The estimate for compound 3 lay 8.7-fold (0.94 log units) above the measured number, and the stated range ends above it.
By their numbers in this assay, from the lowest: compound 3; then compound 2; then compound 1.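

Hydrogen in place of methoxy on an aromatic carbon, ortho to a group of 8 heavy atoms, gives a 4.5-fold lower number from compound 2 to compound 3 (0.65 log units; beyond the scatter) in this assay, so at this place methoxy gives a weaker number than hydrogen. The same exchange starting from compound 1 gives an 11-fold lower number from compound 1 to compound 3 (1.04 log units; beyond the scatter), so both methoxy compounds shown fall behind compound 3, which carries no methoxy. Nothing measured here explains why this is so. On these data alone, whether fluorine or a hydroxy group on this carbon would keep the number of compound 3 stays open, as does whether any group there can improve on hydrogen.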